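Terminal amide variation in a trypsin inhibition series

The source may hold more compounds than are shown below. What is called first, only, known or untested is meant among the compounds shown, and "the series" means these compounds.

Compound 1 `CC(NC(=O)[C@H](CCCCN)NC(=O)[C@H](CCCNC(=N)N)NC(=O)c1ccccc1)(C(N)=O)c1ccccc1` is tested in an assay on isolated protein for inhibition of Trypsin (Homo sapiens), read by fluorescence, with a stated time of 15 min, tested at 50 uM; a higher number here means more inhibition at the concentration tested (going by the name of the read-out), a lower number less inhibition. In this assay compound 1 gives <= 5%, which is a limit of the assay and not a number. Compound 2 `CN(C(=O)c1ccccc1)[C@@H](CCCNC(=N)N)C(=O)N[C@@H](CCCCN)C(=O)N[C@@H](C(N)=O)c1ccccc1` is the second measured member. In this assay compound 2 gives <= 5%, likewise a limit. Compound 1 thus stands at the limit of <= 5% in this assay, at which 2 of the 2 values shown sit; no measured number separates the two compounds.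

Compound 3 `N=C(N)NCCC[C@H](NC(=O)c1ccccc1)C(=O)N[C@@H](CCCCN)C(=O)N(CC(N)=O)c1ccccc1` has not yet been measured in this assay. It differs from compound 1 in one place: (carbamoylmethyl)(phenyl)amino in place of (1-carbamoyl-1-phenylethyl)amino on a carbonyl carbon. Going by the values given here, no step between measured compounds covers this change, so nothing shows what it does to inhibition. The expected step in this assay from compound 1 to compound 3 is none beyond the scatter, a step that the limit leaves unreadable from compound 1 to compound 3, since both measured values sit at the limit of <= 5% in this assay, at which 2 of the 2 values shown sit. For compound 3 the expected inhibition in this assay is 3%, with a range from 0% to 12%, most likely again reported as a limit.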

Compound 3, a percentage reported as inhibition, at one concentration (the size of the read-out at that concentration, not a potency): <= 5%
Compound 3 gave a limit, no number (the forecaster's own chance of this, stated with the estimate: 70%); the middle value lies beyond the limit too.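

No step can be read from compound 1 to compound 3 in this assay, since both results are limits and not numbers: the limit of <= 5% in this assay, at which 3 of the 3 values shown sit.

The compounds shown leave open whether (carbamoylmethyl)(phenyl)amino in place of (1-carbamoyl-1-phenylethyl)amino on a carbonyl carbon changes inhibition at all.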